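Swapping Phenyl for a Thiadiazole on the Amide Carbonyl

A few compounds are considered here, and "the series" means these few. Any claim that something is new, unique, unknown or untested is made for them only; others in the source may bear on it.

Compound 1 `CCCCNc1nc(N)nc2c1CN(C(=O)c1ccccc1)CC2` was tested in an assay on HEK293 cells for agonist activity at Toll-like receptor 8 (Homo sapiens), read by a luciferase reporter, with a stated time of 6 h (on this read-out higher numbers stand for an effect only at larger amounts of compound and lower numbers for an effect already at smaller amounts), where compound 1 gives 1.4 uM. Among the two compounds measured so far, compound 1 has the highest number; its only companion, compound 2 `CCCCNc1nc(N)nc2c1CN(Cc1ccc(C(C)(C)C)cc1)CC2`, gives 0.66 uM in this assay, a lower number that lies beyond the usual scatter. Compound 3 `CCCCNc1nc(N)nc2c1CN(C(=O)c1csnn1)CC2` differs from compound 1 in one place: 1,2,3-thiadiazol-4-yl in place of phenyl on a carbonyl carbon. Going by the values given here, no measured pair shows this change, so only a small step is expected, in either direction or none beyond the scatter: a 1.1-fold higher number from compound 1 to compound 3 (0.03 log units; within the scatter). Compound 3 is estimated to give 1.5 uM, within 0.5 uM to 5 uM.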

Compound 3, minimum effective concentration: 0.1 uM
Compound 3: the middle estimate sits 15-fold (1.18 log units) above what was measured; the measured number lies below the stated range.
By their numbers in this assay, from the lowest: compound 3; then compound 2; then compound 1.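

In this assay, 1,2,3-thiadiazol-4-yl in place of phenyl on a carbonyl carbon gives a 14-fold lower number from compound 1 to compound 3 (1.15 log units; beyond the scatter) and so shows that this position responds strongly to the ring it carries. Compound 2 lacks that carbonyl and differs from compound 1 in more than one place, so it could not show this. Nothing available identifies which feature of the new ring accounts for the step. The compounds shown leave open whether a thiophene, a furan or a pyridine on the same carbonyl carbon would give a similar step. They also leave open whether the sulfur or the ring nitrogens matter more.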